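A second methoxy group enters on compound 3

The source may hold more compounds than are shown below. What is called first, only, known or untested is meant among the compounds shown, and "the series" means these compounds.

Compound 1 `COc1cc2c(Oc3ccc(NC(=O)c4cc(-c5ccccc5)ccn4)cc3F)ccnc2cc1OCCCN1CCCC1`: 130 nM
Compound 2 `COc1cc2c(Oc3ccc(NC(=O)c4cc(-c5ccccc5C)ccn4)cc3F)ccnc2cc1OCCCN1CCCC1`: 420 nM
Compound 3 `COc1ccc(-c2ccnc(C(=O)Nc3ccc(Oc4ccnc5cc(OCCCN6CCCC6)c(OC)cc45)c(F)c3)c2)cc1`: 200 nM

Of the compounds shown here, three share one core and have been tested in a functional assay on NCI-H460 cells (Homo sapiens) for cytotoxicity, read by MTT assay, with a stated time of 72 h; on this read-out lower numbers stand for stronger inhibition and higher numbers for weaker inhibition. Compound 3 gives 200 nM, the second highest of the three numbers; compound 1 sits within the scatter of it, whereas the step of a 2.1-fold lower number from compound 2 to compound 3 (0.32 log units; beyond the scatter) lies beyond it. Compound 4 `COc1ccc(-c2ccnc(C(=O)Nc3ccc(Oc4ccnc5cc(OCCCN6CCCC6)c(OC)cc45)c(F)c3)c2)c(OC)c1` differs from compound 3 by methoxy in place of hydrogen on an aromatic carbon. Within the data shown here, two measured steps bear on this. The earlier methoxy addition gave a 1.5-fold higher number from compound 1 to compound 3 (0.19 log units; within the scatter), while a methyl placed ortho to the large group gave a 3.2-fold higher number from compound 1 to compound 2 (0.51 log units; beyond the scatter). Since the new methoxy also enters ortho to a large group, a modest rise in this assay is expected, a 1.8-fold higher number from compound 3 to compound 4 (0.24 log units; within the scatter). Compound 4 is therefore estimated at 350 nM, within 150 nM to 900 nM.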

Compound 4, half-maximal inhibitory concentration: 520 nM
Beside the measured number, compound 4's estimate is 1.5-fold (0.17 log units) below it; measured number inside the range.
By their numbers in this assay, from the lowest: compounds 1 and 3 (each within the scatter of the next); then compounds 2 and 4 (each within the scatter of the next).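

In this assay, methoxy ortho to a large group gives a 2.6-fold higher number from compound 3 to compound 4 (0.41 log units; beyond the scatter) and so moves the number beyond the scatter, unlike the earlier methoxy step, a 1.5-fold higher number from compound 1 to compound 3 (0.19 log units; within the scatter) on the same ring. The 2,4-dimethoxyphenyl and 2-methylphenyl groups are not separated here, with a 1.2-fold higher number from compound 2 to compound 4 (0.09 log units; within the scatter) inside the scatter, while replacing phenyl with 2,4-dimethoxyphenyl gives a 4.0-fold higher number from compound 1 to compound 4 (0.60 log units; beyond the scatter) in this small set. Nothing shown here accounts for these steps. Still open, from the compounds shown here alone, is whether methoxy ortho to a large group acts the same without the second methoxy, and whether an amine or hydroxyl group there would follow suit.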